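A few compounds are considered here, and "the series" means these few. Any claim that something is new, unique, unknown or untested is made for them only; others in the source may bear on it.

Compound 1 `CC(C)C[C@H](N)CN(C(=O)[C@@H]1C[C@H]1c1ccccc1)c1ccc(-c2ccccc2)cc1`: 880 nM
Compound 2 `CC(C)[C@H](N)CN(C(=O)[C@@H]1C[C@H]1c1ccccc1)c1ccc(-c2ccccc2)cc1`: 1.1 nM
Compound 3 `CC(C)CCNCCN(C(=O)[C@@H]1C[C@H]1c1ccccc1)c1ccc(-c2ccccc2)cc1`: 5.1 nM

All three were tested in a functional assay for agonist activity at G protein-coupled receptor 88 (Homo sapiens), read by HTRF and cAMP accumulation; on this read-out higher numbers stand for an effect only at larger amounts of compound and lower numbers for an effect already at smaller amounts. Compound 3 stands between the other two: against compound 2 it shows a higher number, a 4.6-fold higher number from compound 2 to compound 3 (0.67 log units; beyond the scatter), while against compound 1 it shows a far lower number, a 170-fold lower number from compound 1 to compound 3 (2.24 log units; beyond the scatter). Compound 4 `O=C([C@@H]1C[C@H]1c1ccccc1)N(CCNCC1CCCCC1)c1ccc(-c2ccccc2)cc1` is reached from compound 3 by a single change, (cyclohexyl in place of isobutyl on a saturated chain carbon bound to an amine nitrogen). Within the data shown here, no measured pair shows this exact swap. The step of an 800-fold lower number from compound 1 to compound 2 (2.90 log units; beyond the scatter) shows that exchanging one branched alkyl group for another at a saturated chain carbon bound to an amine nitrogen can move the number enormously, but that carbon carries a primary amine rather than the chain amine of compound 3, so it is only a loose guide. The step of a 4.6-fold higher number from compound 2 to compound 3 (0.67 log units; beyond the scatter) rearranges the amine itself, not its alkyl tail. Among the measured compounds shown here, with no close precedent, only a modest step is expected in this assay, if any beyond the scatter, in either direction, and the estimated step is a 1.0-fold lower number from compound 3 to compound 4 (0.01 log units; within the scatter). Compound 4 is therefore expected to give about 5 nM, within 1.5 nM to 20 nM.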

Compound 4, half-maximal effective concentration: 6.6 nM
For compound 4 the middle estimate is 1.3-fold (0.12 log units) below the measured one, and the stated range covers the measured number.
By their numbers in this assay, from the lowest: compound 2; then compounds 3 and 4 (each within the scatter of the next); then compound 1.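

In this assay the step of a 1.3-fold higher number from compound 3 to compound 4 (0.11 log units; within the scatter) lies within the scatter, so at this saturated chain carbon bound to an amine nitrogen, a cyclohexyl ring serves as well as the open isobutyl group. Compound 4 also sits much as compound 3 does against the two compounds with a primary amine, with a 6.0-fold higher number from compound 2 to compound 4 (0.78 log units; beyond the scatter) and a 130-fold lower number from compound 1 to compound 4 (2.12 log units; beyond the scatter) in this assay, so the larger ringed tail leaves that earlier picture unchanged. Nothing available here explains why the swap makes so little difference.

The compounds shown leave open whether a phenyl ring in place of cyclohexyl, or a tail carrying a hydroxyl group or a carboxylic acid, would be tolerated in the same way. They also leave open what a methyl group on the chain amine nitrogen would do.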